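Amide Aryl Swap on a Flavonol Core: Methoxy for Chloro

The compounds below may be only part of what the source reports. "The series", "measured", "known", "first", "only" and "open" are said of these compounds alone.

Compound 1 `O=C(Nc1cccc(-c2oc3cc(-c4ccc(F)cc4)ccc3c(=O)c2O)c1)c1ccc(Cl)cc1` carries a 4-chlorophenyl group on the amide carbonyl. Among the compounds with values here, in a functional assay on HepG2 cells (Homo sapiens) for antiproliferative activity, read by CCK-8 assay, with a stated time of 72 h (a higher number here means a weaker inhibitor, a lower number a stronger inhibitor), compound 1 gives 11000 nM, the lower of the two numbers so far; its nearest neighbour is compound 2 `Cc1ccccc1C(=O)Nc1cccc(-c2oc3cc(-c4ccc(F)cc4)ccc3c(=O)c2O)c1`, which in this assay gives 19400 nM. Within the data shown here, the single measured step, a 1.8-fold higher number from compound 1 to compound 2 (0.25 log units; within the scatter), replaces the 4-chlorophenyl with 2-methylphenyl and stays inside the scatter, so the carbonyl-bound aryl group has so far not moved the number beyond noise.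

Compound 3 `COc1cccc(C(=O)Nc2cccc(-c3oc4cc(-c5ccc(F)cc5)ccc4c(=O)c3O)c2)c1` makes a related change: 3-methoxyphenyl in place of 4-chlorophenyl on a carbonyl carbon. Among the measured compounds shown here, only the step from compound 1 to compound 2 bears on it, and that step was small. Compound 3 is therefore expected to land close to compound 1, with no step beyond the scatter, a 1.4-fold higher number from compound 1 to compound 3 (0.13 log units; within the scatter). The estimate for compound 3 in this assay is 15000 nM, with a range from 7000 nM to 35000 nM.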

Compound 3, half-maximal inhibitory concentration: 9950 nM
Compound 3: the middle estimate sits 1.5-fold (0.18 log units) above what was measured, within the range that was stated.
By their numbers in this assay, from the lowest: compounds 3, 1 and 2 (each within the scatter of the next).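

In this assay, putting 3-methoxyphenyl in place of 4-chlorophenyl on the carbonyl carbon gives a 1.1-fold lower number from compound 1 to compound 3 (0.04 log units; within the scatter), and putting it in place of 2-methylphenyl gives a 1.9-fold lower number from compound 2 to compound 3 (0.29 log units; within the scatter). The earlier compounds shown here offered a single step at this position, whereas three aryl groups now sit within the scatter of one another, including one that brings a hydrogen-bond acceptor where 4-chlorophenyl has none. No measurement shown here explains this result.

From the compounds shown here alone, all three groups at this position contain one six-membered aromatic ring of carbon only, so it remains open how an aminomethyl group, a carboxylic acid or a longer alkyl chain on the carbonyl carbon would behave. Going by these compounds, it also remains open whether a change elsewhere on the shared core would move the number beyond the scatter.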